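Two Related Compounds, and a Third One Awaiting Measurement

The source may report more compounds than this note shows. Statements on the series, on what has been measured and on what is new or still open speak of the compounds shown alone.

Measured so far:
Compound 1, `CCCN(CC1CC1)C(=O)c1c(C)nc2n(-c3c(C)cc(C)cc3C)c(Cl)cn12`: 61 nM
Compound 2, `CCCCN(CC)Cc1c(C(F)(F)F)nc2n(-c3c(C)cc(C)cc3C)c(Cl)cn12`: 78 nM

In an assay on cells for displacement of a labelled ligand from corticotropin-releasing factor receptor 1 (Homo sapiens), with a stated time of 100 min (on this read-out higher numbers stand for weaker inhibition and lower numbers for stronger inhibition), compound 1 gives 61 nM. In this assay compound 2 gives 78 nM. These two numbers sit close together; the gap between them is within the usual spread of repeated measurements, so neither compound can be said to bind more tightly than the other on this evidence.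

Compound 3, `C=CCN(CC=C)Cc1c(C(F)(F)F)nc2n(-c3c(C)cc(C)cc3C)c(Cl)cn12`, has not yet been measured. It differs from compound 2 in one place: diallylamino in place of butyl(ethyl)amino on a saturated chain carbon bound to an aromatic carbon. Among the measured compounds shown here, no pair of measured compounds shows what such a swap does, so there is no measured step to lean on. The group that leaves and the group that enters are of the same size, and on that basis no change beyond the scatter is expected. The estimated step of a 1.0-fold lower number from compound 2 to compound 3 (0.02 log units; within the scatter) is therefore small. Compound 3 is expected to give 75 nM in this assay, with a likely range from 25 nM to 220 nM.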

Compound 3, inhibition constant: 13 nM
The estimate for compound 3 lay 5.8-fold (0.76 log units) above the measured number, and the stated range ends above it.
By their numbers in this assay, from the lowest: compound 3; then compounds 1 and 2 (each within the scatter of the next).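

In this assay, putting diallylamino in place of butyl(ethyl)amino on a saturated chain carbon bound to an aromatic carbon gives a 6.0-fold lower number from compound 2 to compound 3 (0.78 log units; beyond the scatter), so the groups at this place are not interchangeable. The two groups have the same count of heavy atoms, and neither has a ring, so matching these counts does not guarantee a matching result; diallylamino does differ in carrying 2 double bonds outside aromatic rings. No measurement shown explains the step.

A single step cannot show whether the double bonds matter or whether the difference lies in the two chains being of equal length rather than unequal. Dipropylamino, which has two equal chains and no double bonds, would separate these possibilities, while a cyclic amine such as piperidine would show how this place responds when the chains are joined into a ring.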